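Oxanylamino Propenyl Chain Replaces Thianylmethyl on an Inactive Scaffold

The compounds below may be only part of what the source reports. "The series", "measured", "known", "first", "only" and "open" are said of these compounds alone.

The measured compounds, all tested in a functional assay on cells for agonist activity at C-X-C chemokine receptor type 4 (Homo sapiens), read by fluorescence and calcium flux, with a stated time of 90 s; a lower number here means that less compound is needed, a higher number that more compound is needed for the effect:

Compound 1 `c1ccc(CN(CCCCN(C[C@H]2Cc3ccccc3CN2)[C@H]2CCCc3cccnc32)Cc2ccccc2)cc1` gives > 30000 nM, which is a limit of the assay rather than a number.
Compound 2 `c1ccc2c(c1)CN[C@@H](CN(CCCCNCC1CCSCC1)[C@H]1CCCc3cccnc31)C2` gives > 30000 nM, again only a limit.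
Compound 3 `CC1(C)CCC(NCCCCN(C[C@H]2Cc3ccccc3CN2)[C@H]2CCCc3cccnc32)CC1` gives > 30000 nM, again only a limit.

Compound 2 therefore stands nowhere definite on the scale: its value is a limit, and the same holds for every other measured compound, since all three sit at the limit of > 30000 nM in this assay, at which 3 of the 3 values shown sit. Among the compounds with values here, the only one-point step among them, a step that the two limits leave unreadable from compound 2 to compound 3, cannot be read for that reason, so it tells nothing about what a change at this amine nitrogen does.

Compound 4 `C(=C/CN(C[C@H]1Cc2ccccc2CN1)[C@H]1CCCc2cccnc21)\CNC1CCOCC1` differs from compound 2 in one place: a group of 10 heavy atoms (8 carbon, 1 nitrogen, 1 oxygen; one six-membered non-aromatic ring with 1 hetero atom) in place of a group of 11 heavy atoms (9 carbon, 1 nitrogen, 1 sulfur; one six-membered non-aromatic ring with 1 hetero atom), on a saturated chain carbon bound to an amine nitrogen.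

With no readable step and every comparator at the limit, the expectation for compound 4 rests on the pattern of compounds 1, 2 and 3 alone, and so compound 4 is expected to reach only the same limit. Compound 4 is thus estimated at about 30000 nM, within 10000 nM to 100000 nM. The estimated step of a number no higher from compound 2 to compound 4 (the limit leaves the size open) is expected to be none beyond the scatter, with a high chance that only a limit is reported.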

Compound 4, half-maximal effective concentration: > 30000 nM
Compound 4: only a limit was reported; the forecaster's own chance of this, stated with the estimate: 75%; the middle value lies on the limit itself.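

The step from compound 2 to compound 4 cannot be read, because both compounds reach only a limit of the assay: the limit of > 30000 nM in this assay, at which 4 of the 4 values shown sit.

The compounds shown leave open how much compound, if any, would give an effect in this assay, and whether the change from compound 2 to compound 4 alters that amount.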